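Swapping Acetyl for Ethoxycarbonyl: What to Expect for Compound 4

This account rests on a few compounds, and the source may have more. Where it says the series, first, only, none or still open, it means among the compounds named here.

Measured so far in a functional assay on MCF7 cells (Homo sapiens) for cytotoxicity, read by sulforhodamine B assay, with a stated time of 72 h; a higher number here means a weaker inhibitor, a lower number a stronger inhibitor:
compound 1 `CC(=O)c1nn(-c2ccc(Cl)cc2)/c(=N/c2nc(-c3c(C)n(C)n(-c4ccccc4)c3=O)cs2)s1` gives > 100000 nM, which is a limit of the assay.
compound 2 `CC(=O)c1nn(-c2ccc(C)cc2)/c(=N/c2nc(-c3c(C)n(C)n(-c4ccccc4)c3=O)cs2)s1` gives 56800 nM.
compound 3 `COc1ccc(-n2nc(C(C)=O)s/c2=N\c2nc(-c3c(C)n(C)n(-c4ccccc4)c3=O)cs2)cc1` gives 64500 nM.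

Compound 1 has only a limit of the assay as its result, so no number is known for it. Compound 2 gives 56800 nM in this assay, and compound 3 gives 64500 nM. All three compounds share one core and differ only in the group on the aromatic ring that carries chloro in compound 1. The measured steps are an at least 1.7-fold lower number from compound 1 to compound 2 (0.24 log units; that floor lies within the scatter), an at least 1.5-fold lower number from compound 1 to compound 3 (0.19 log units; that floor lies within the scatter) and a 1.1-fold higher number from compound 2 to compound 3 (0.06 log units; within the scatter); none of them moves beyond the scatter.

Compound 4 `CCOC(=O)c1nn(-c2ccc(Cl)cc2)/c(=N/c2nc(-c3c(C)n(C)n(-c4ccccc4)c3=O)cs2)s1` changes a different place: ethoxy in place of methyl on a carbonyl carbon. Going by the values given here, no measured step touches this position, so none of the three steps bears directly on it. What the measured compounds show is that every change made so far left the compounds weak, and compound 1 sits at the limit (the limit of > 100000 nM in this assay, at which 1 of the 3 values shown sits). Compound 4 is therefore expected to remain weak, with an expected step of an at least 1.1-fold lower number from compound 1 to compound 4 (0.04 log units; that floor lies within the scatter) that is not clearly beyond the scatter. The estimate for compound 4 is 90000 nM, with a range from 30000 nM to 300000 nM, and a real chance that this assay again reports only a limit.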

Compound 4, half-maximal inhibitory concentration: > 100000 nM
Compound 4: only a limit was reported (the forecaster's own chance of this, stated with the estimate: 55%); at least 1.1-fold (0.04 log units) between middle value and limit.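

In this assay compound 4 gives > 100000 nM, which is a limit of the assay and not a number. Compound 1 also has only a limit, so the step from compound 1 to compound 4 cannot be read: the limit of > 100000 nM in this assay, at which 2 of the 4 values shown sit. The compounds shown leave open whether ethoxycarbonyl in place of acetyl changes the result at all, and how weak compound 1 and compound 4 really are.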